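This account rests on a few compounds, and the source may have more. Where it says the series, first, only, none or still open, it means among the compounds named here.

Working notes on a set of compounds built around the core seen in compound 1, `C[C@H](NC(=O)CN(c1nc(Cl)nc2[nH]cnc12)C1CC1)C(=O)OCc1ccccc1`. In a functional assay on the whole organism (Tail, strain ICR) with Mus musculus as the target, in the tail flick test, with a stated time of 30 min, at a dose of 25 umol/kg by the oral route (a lower number here means a weaker effect, a higher number a stronger effect of the compound at the dose given), compound 1 gives 41.2%. Compound 2, `O=C(CN(c1nc(Cl)nc2[nH]cnc12)C1CC1)N[C@@H](CO)C(=O)O`, gives 38.7% in this assay, and compound 3, `O=C(OCc1ccccc1)[C@@H]1CCCN1C(=O)CN(c1ncnc2c1ncn2C1CCCCO1)C1CC1`, gives 32.3%. Compound 1 thus holds the highest of the three numbers, yet its gaps to compound 2 and to compound 3 both lie within the usual scatter, so no order among the three can be claimed.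

Compound 4, `NCCCC[C@H](NC(=O)CN(c1nc(Cl)nc2[nH]cnc12)C1CC1)C(=O)OCc1ccccc1`, has not yet been measured in this assay. Its change from compound 1 reads (3-aminopropyl in place of hydrogen on a saturated chain carbon, two bonds along the chain from an amide-type nitrogen and a carbonyl carbon). Going by the values given here, no measured pair of this kind is at hand, so the size of the step in this assay can only be estimated. Given that the three measured compounds sit within the scatter of one another despite differing at several places, the expectation is no step beyond the scatter, in either direction. The expected step in this assay is therefore a number 3.2 percentage points lower from compound 1 to compound 4 (within the scatter). Compound 4 is estimated at 38%, with a range from 18% to 58%.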

Compound 4, a percentage reported as activity, at one dose (the size of the read-out at that dose, not a potency): 26.1%
Beside the measured number, compound 4's estimate is 11.9 percentage points above it; low and high end bracket the measured number.
By their numbers in this assay, from the lowest: compounds 4, 3, 2 and 1 (each within the scatter of the next, the first and the last beyond it).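

In this assay the series now has its first pair that differs in one place: 3-aminopropyl in place of hydrogen on a saturated chain carbon, two bonds along the chain from an amide-type nitrogen and a carbonyl carbon, gives a number 15.1 percentage points lower from compound 1 to compound 4 (beyond the scatter) and so shows that the read-out at the dose given responds to a change at this position. Going by these compounds alone, the earlier compounds offered no such pair, as each differed from the others in more than one place, so this is the only single change whose size can be read so far. No measurement at hand speaks to the reason for this step.

The compounds shown leave open whether the step goes with the amine or with the added chain itself, a question that a plain butyl group at the same place, read against the 4-aminobutyl of compound 4, would help to settle. Also open, going by these compounds, are how a shorter 2-aminoethyl chain or a carboxylic acid at the chain end would read against compound 1, and whether the same change gives a similar step on the other compounds.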